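The source may report more compounds than this note shows. Statements on the series, on what has been measured and on what is new or still open speak of the compounds shown alone.

Going by the values given here, of the three compounds measured so far, only compound 2 `O=C1O[C@H]([C@@H](O)Cn2cc(-c3ccc(Br)cc3)nn2)C(OCc2ccccc2)=C1OCc1ccccc1` gives a number: in a functional assay on CFPAC-1 cells (Homo sapiens) for antiproliferative activity, read by MTT assay, with a stated time of 72 h (on this read-out lower numbers stand for stronger inhibition and higher numbers for weaker inhibition), compound 2 reaches 5830 nM. Compound 1 `O=C1O/C(=C\Cn2cc(-c3ccc(Br)cc3)nn2)C(OCc2ccccc2)=C1OCc1ccccc1` gives > 100000 nM, which is a limit of the assay rather than a number. Compound 3 `CC(C)(C)OC(=O)N1CCN(C(=S)SCc2cn(C[C@H](O)[C@H]3OC(=O)C(OCc4ccccc4)=C3OCc3ccccc3)nn2)CC1` likewise gives > 100000 nM, again a limit. Among the compounds with values here, two of the three results therefore sit at the limit of > 100000 nM in this assay, at which 2 of the 3 values shown sit, and compound 2 stands alone as the one measurable value. Compound 4 `O=C1O[C@H]([C@@H](O)Cn2cc(CNS(=O)(=O)c3ccc(F)cc3)nn2)C(OCc2ccccc2)=C1OCc1ccccc1` differs from compound 2 in one place: (((4-fluorophenyl)sulfonyl)amino)methyl in place of 4-bromophenyl on an aromatic carbon. Within the data shown here, no pair of measured compounds differs in a single place, so no step size can be read directly from the data. Compound 3 also carries a substituent other than 4-bromophenyl in the same place and reached only the limit, which argues for caution. Compound 4 is therefore expected to lose some activity, with an estimated step of a 3.4-fold higher number from compound 2 to compound 4 (0.54 log units; beyond the scatter). The estimate for compound 4 is 20000 nM, with an expected range from 5000 nM to 100000 nM.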

Compound 4, half-maximal inhibitory concentration: 34700 nM
The estimate for compound 4 lay 1.7-fold (0.24 log units) below the measured number, within the range that was stated.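

This position now has its first readable step in this assay: (((4-fluorophenyl)sulfonyl)amino)methyl in place of 4-bromophenyl gives a 6.0-fold higher number from compound 2 to compound 4 (0.77 log units; beyond the scatter). Inhibition weakens, yet compound 4 still gives a real number rather than a limit, so a measurable value at this position does not depend on 4-bromophenyl. Nothing shown here explains the loss, since the new group differs in several ways at once, including its size, its sulfonyl and its added methyl link.

Going by these compounds, it remains open which of those differences accounts for the step, for example whether a plain 4-fluorophenyl on the same carbon would behave like 4-bromophenyl. On these data alone, it is also open how a small amine, a carboxylic acid or a longer carbon chain would fare at this position.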